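A few compounds are considered here, and "the series" means these few. Any claim that something is new, unique, unknown or untested is made for them only; others in the source may bear on it.

Measured compounds in a functional assay on HeLa cells (Homo sapiens) for cytotoxicity, read by MTT assay, with a stated time of 72 h; on this read-out higher numbers stand for weaker inhibition and lower numbers for stronger inhibition:
- compound 1 `NS(=O)(=O)c1cc(-c2nnc(CN3CCN(c4ccc(F)cc4)CC3)o2)c(Cl)cc1SCc1ccccc1` gives 10000 nM
- compound 2 `NC(=O)c1cn(Cc2nnc(-c3cc(S(N)(=O)=O)c(SCc4ccccc4)cc3Cl)o2)nn1` gives 75000 nM

Of these two numbers, compound 2 holds the higher one, the weaker inhibition, and its gap to compound 1 lies beyond the usual scatter. Compound 3 `NS(=O)(=O)c1cc(-c2nnc(/C=C/c3cccc(Cl)c3)o2)c(Cl)cc1SCc1ccccc1` has not yet been measured in this assay. It differs from compound 2 in a single place: 2-(3-chlorophenyl)ethenyl in place of (4-carbamoyl-1H-1,2,3-triazol-1-yl)methyl on an aromatic carbon. Among the measured compounds shown here, no measured pair shows this exact exchange, so the size of the step rests on compound 1 alone, whose different group at the same position comes with 10000 nM. On that footing, the step from compound 2 to compound 3 is expected to run toward a lower number, that is, toward stronger inhibition, with an expected size of a 3.8-fold lower number from compound 2 to compound 3 (0.57 log units; beyond the scatter). Compound 3 is therefore estimated at 20000 nM, within a range from 4000 nM to 100000 nM.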

Compound 3, half-maximal inhibitory concentration: 16000 nM
For compound 3 the middle estimate is 1.3-fold (0.10 log units) above the measured one, within the range that was stated.
By their numbers in this assay, from the lowest: compounds 1 and 3 (each within the scatter of the next); then compound 2.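

In this assay, the exchange of (4-carbamoyl-1H-1,2,3-triazol-1-yl)methyl for 2-(3-chlorophenyl)ethenyl on the aromatic carbon of the five-membered ring gives a 4.7-fold lower number from compound 2 to compound 3 (0.67 log units; beyond the scatter). Among the compounds shown here, this is the first single change read directly at this position, and it shows that the number there responds to the group attached, even though both groups have 9 heavy atoms. Compound 3 also lies within the scatter of compound 1, so two quite different groups at this position, one with no hydrogen-bond donors or acceptors, give matching numbers, and no measurement shown here explains the shift.

Going by these compounds, whether the chlorine on the phenyl ring matters remains open, since a plain 2-phenylethenyl group would be needed to tell. Also open, on these data alone, is how a saturated ethyl link in place of the ethenyl, or a carboxylic acid at this position, would change the number.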